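Replacing the ethynylpyridine group of a weak growth inhibitor

A few compounds are considered here, and "the series" means these few. Any claim that something is new, unique, unknown or untested is made for them only; others in the source may bear on it.

Two compounds have been measured so far in a functional assay on Maver1 cells (Homo sapiens) for inhibition, read by XTT assay, with a stated time of 72 h (a higher number here means a weaker inhibitor of growth, a lower number a stronger inhibitor of growth), so far:
Compound 1 `C=Cc1ccnc(C#Cc2ccc3ncn(-c4ccnc(N)n4)c3c2)c1` gives 501 nM
Compound 2 `C#Cc1ccnc(C#Cc2ccc3ncn(-c4ccnc(N)n4)c3c2)c1` gives 10000 nM

Compound 2 holds the higher of the two numbers, and compound 1 is its nearest neighbour. In compound 3 `C=Cc1ccnc(C#Cc2ccc3ncn(-c4ccnc(N)n4)c3c2)n1` the change from compound 2 is a group of 8 heavy atoms (6 carbon, 2 nitrogen; one six-membered aromatic ring with 2 hetero atoms) in place of a group of 8 heavy atoms (7 carbon, 1 nitrogen; one six-membered aromatic ring with 1 hetero atom), on a triple-bonded carbon and the entering group holds a double bond outside aromatic rings where the leaving group holds a triple bond. Among the measured compounds shown here, one measured step bears on this: ethynyl in place of vinyl on an aromatic carbon gave a 20-fold higher number from compound 1 to compound 2 (1.30 log units; beyond the scatter) and that large step leads to the expectation of a lower number for compound 3. For the measured compounds named here, no measured step covers the ring with 2 hetero atoms, so only part of that size is expected. The expected change is a 6.7-fold lower number from compound 2 to compound 3 (0.82 log units; beyond the scatter) in this assay as an estimate only. Compound 3 is estimated at 1500 nM within an expected range from 300 nM to 8000 nM until it is measured.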

Compound 3, concentration for 50% growth inhibition: 1260 nM
The estimate for compound 3 lay 1.2-fold (0.08 log units) above the measured number, and the stated range covers the measured number.
By their numbers in this assay, from the lowest: compound 1; then compound 3; then compound 2.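

In this assay, the exchange on the triple-bonded carbon gave a 7.9-fold lower number from compound 2 to compound 3 (0.90 log units; beyond the scatter), which shows that a ring with 2 hetero atoms bearing a vinyl group is tolerated here far better than 4-ethynylpyridin-2-yl. The added ring hetero atom still has a cost, though: with the vinyl group kept, the change gave a 2.5-fold higher number from compound 1 to compound 3 (0.40 log units; beyond the scatter), so the pyridine ring with a vinyl group retains the lowest number of the three. No evidence is available that would explain either step.

The compounds shown leave open whether an amine, a methoxy group or a longer alkyl chain in place of the vinyl group would lower the number further on either ring. They also leave open how an ethynyl group would fare on the ring with 2 hetero atoms.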